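Capping an Aromatic Amine on a Chalcone Core

This account rests on a few compounds, and the source may have more. Where it says the series, first, only, none or still open, it means among the compounds named here.

Compound 1 `COc1ccc(/C=C/C(=O)c2ccc(N)c(-c3ccc(F)cc3)c2)cc1OC` carries an amino group on its core. Among the compounds with values here, in a functional assay on MCF7 cells (Homo sapiens) for cytotoxicity, read by sulforhodamine B assay, with a stated time of 48 h (on this read-out higher numbers stand for weaker inhibition and lower numbers for stronger inhibition), compound 1 gives 15000 nM, one of only two numbers recorded so far. Compound 3 `O=C(/C=C/c1cccc(Br)c1)c1cccc(-c2cccc(F)c2)c1` in this assay gives 12700 nM, which sits within the usual scatter of the number for compound 1, so the two cannot be told apart. Compound 2 `COc1ccc(/C=C/C(=O)c2cccc(-c3cccc(F)c3)c2)cc1O` in this assay gives "not determined" (no result reported), so no number is available for it. Compound 4 `COc1ccc(/C=C/C(=O)c2ccc(NC(C)=O)c(-c3ccc(F)cc3)c2)cc1OC` differs from compound 1 in one place: acetyl in place of hydrogen on a nitrogen on an aromatic ring. Within the data shown here, no measured pair shows this change, so there is no direct guide. Given the two measured numbers lie close together, the expected step of a 1.2-fold lower number from compound 1 to compound 4 (0.06 log units; within the scatter) is small, within the scatter, in no firm direction. Compound 4 is therefore expected to give about 13000 nM in this assay, with a range from 4000 nM to 40000 nM.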

Compound 4, half-maximal inhibitory concentration: 15000 nM
Estimate against measurement, compound 4: 1.2-fold (0.06 log units) below, and the stated range covers the measured number.
By their numbers in this assay, from the lowest: compounds 3, 1 and 4 (each within the scatter of the next).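

Acetyl in place of hydrogen on this nitrogen gives the first direct reading at this position: in this assay there is no change at the digits printed from compound 1 to compound 4 (within the scatter) for this change from amino to acetamido. On the core of compound 1, then, this nitrogen accepts the acetyl group with no visible shift, though one pair supports no wider rule. Nothing measured here offers an explanation for this result. Going by these compounds, whether a longer chain such as butanoyl, or a methylsulfonyl group, on this nitrogen would read differently stays open.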